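The source may report more compounds than this note shows. Statements on the series, on what has been measured and on what is new or still open speak of the compounds shown alone.

Compound 1 `COc1cc(/C=N/c2c(C#N)ncn2-c2ccc(F)cc2)cc(OC)c1OC` and compound 2 `N#Cc1ncn(-c2ccc(F)cc2)c1/N=C/c1ccc([N+](=O)[O-])cc1` share a five-membered aromatic ring bearing a cyano group and a 4-fluorophenyl on a ring nitrogen; the difference between the two cores is not broken down here. In a functional assay on T47D cells (Homo sapiens) for antiproliferative activity, read by MTT assay, with a stated time of 48 h (on this read-out lower numbers stand for stronger inhibition and higher numbers for weaker inhibition), compound 1 gives 13700 nM and compound 2 gives 15900 nM, two numbers that lie within the scatter of each other.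

Compound 3 `COc1cc(/C=N/c2c(C#N)ncn2Cc2ccc(F)cc2)cc(OC)c1OC` arises from compound 1 by the change (4-fluorobenzyl in place of 4-fluorophenyl on an aromatic nitrogen), and in this assay compound 3 gives 17500 nM, a step of a 1.3-fold higher number from compound 1 to compound 3 (0.11 log units; within the scatter).

Compound 4 `N#Cc1ncn(Cc2ccc(F)cc2)c1/N=C/c1ccc([N+](=O)[O-])cc1` arises from compound 2 by the same change, (4-fluorobenzyl in place of 4-fluorophenyl on an aromatic nitrogen). Because the first step was a 1.3-fold higher number from compound 1 to compound 3 (0.11 log units; within the scatter), a step of about the same size is expected here, a 1.3-fold higher number from compound 2 to compound 4 (0.10 log units; within the scatter). Compound 4 is therefore estimated to give 20000 nM in this assay, most likely between 10000 nM and 40000 nM.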

Compound 4, half-maximal inhibitory concentration: 5720 nM
Compound 4: the middle estimate sits 3.5-fold (0.54 log units) above what was measured; measured number below the stated range.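

In this assay, replacing 4-fluorophenyl with 4-fluorobenzyl on the aromatic nitrogen gives a 2.8-fold lower number from compound 2 to compound 4 (0.44 log units; beyond the scatter), and this does not match the earlier result for the same change on the other core: the same change on two cores in this assay, a 1.3-fold higher number (0.11 log units; within the scatter) from compound 1 to compound 3 and a 2.8-fold lower number (0.44 log units; beyond the scatter) from compound 2 to compound 4, 3.6-fold (0.55 log units) apart, beyond the scatter of two such steps. The size and even the direction of this step therefore cannot simply be carried from one core to the other in this series. These two pairs do not show why the steps differ, and two cores give no rule for predicting a third.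

From the compounds shown here alone, it remains open how a longer chain, such as 2-(4-fluorophenyl)ethyl, would behave on the same aromatic nitrogen. Going by these compounds, it is also open whether an amine in place of the fluorine would give different steps on the two cores.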